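The source may report more compounds than this note shows. Statements on the series, on what has been measured and on what is new or still open speak of the compounds shown alone.

Measured so far:

Compound 1 `Nc1nc(Cl)c2ncn(Cc3ccccc3CCl)c2n1` gives 3890 nM in a functional assay on LOX IMVI cells (Homo sapiens) for cytotoxicity, read by sulforhodamine B assay, with a stated time of 48 h; on this read-out higher numbers stand for weaker inhibition of growth and lower numbers for stronger inhibition of growth.
Compound 2 `ClCc1ccccc1Cn1cnc2nc(Cl)nc(Cl)c21` gives 160 nM in this assay.
Compound 3 `ClCc1ccc(Cn2cnc3c(Cl)nc(Cl)nc32)cc1` gives 2040 nM in this assay.

Among these three, compound 2 has the lowest number, and so the strongest growth inhibition: compound 3 sits at a higher number, and compound 1 at a higher number still, both gaps beyond the scatter of this assay.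

The next compound is compound 4 `ClCc1ccccc1Cn1cnc2ncnc(Cl)c21`, which has not yet been measured. It comes from compound 2 by one change: hydrogen in place of chloro on an aromatic carbon. Going by the values given here, nothing measured so far tracks exactly this change, so there is no measured step to lean on; the estimate rests on compound 2 alone and on the fact that the other two compounds, which also differ from compound 2 around the shared core, both give weaker growth inhibition. The expectation for this assay is therefore a step toward a higher number from compound 2 to compound 4, of moderate size: a 6.3-fold higher number from compound 2 to compound 4 (0.80 log units; beyond the scatter) is the estimated step. On that basis compound 4 is expected to give about 1000 nM, within a range of 300 nM to 3500 nM.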

Compound 4, concentration for 50% growth inhibition: 1340 nM
Compound 4: middle estimate off by 1.3-fold (0.13 log units), on the low side, and the stated range covers the measured number.
By their numbers in this assay, from the lowest: compound 2; then compounds 4, 3 and 1 (each within the scatter of the next, the first and the last beyond it).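

Putting hydrogen in place of chloro on the aromatic carbon between two ring nitrogen atoms gives, in this assay, an 8.4-fold higher number from compound 2 to compound 4 (0.92 log units; beyond the scatter). Going by these compounds alone, this is the first comparison in the set that changes only one place, so the loss of growth inhibition can be tied to this single swap rather than to several differences at once. Compound 4 keeps its other chloro group, so that group alone does not preserve the low number of compound 2, yet nothing measured here explains why this position counts.

On these data alone, only chloro and hydrogen can be compared at this carbon, so it remains open whether fluoro, a methyl group or a methoxy group would stay near compound 2 or fall nearer compound 4. As far as these compounds go, it is also open whether the same swap would have a similar effect with the chloromethyl group in the other position on the benzene ring, as in compound 3.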